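A Row of Limits and One Untested Swap

The source may hold more compounds than are shown below. What is called first, only, known or untested is meant among the compounds shown, and "the series" means these compounds.

- compound 1 (`C=C[C@@](C)(/C=C/c1ccc(OS(=O)(=O)C(F)(F)F)cc1)CCC=C(C)C`) gives the limit > 36600 nM in the same test
- compound 2 (`C=C[C@@](C)(/C=C/c1ccc(Nc2ccc(F)cc2)cc1)CCC=C(C)C`) gives the limit > 36600 nM in the same test
- compound 3 (`C=C[C@@](C)(/C=C/c1ccc(Nc2ccc(Cl)c(Cl)c2)cc1)CCC=C(C)C`) gives the limit > 36600 nM in the same test

In an ADME assay on BJ cells (Homo sapiens) for cytotoxicity, with a stated time of 72 h (a higher number here means that more compound is needed for the effect, a lower number that less compound is needed), compound 3 has no exact number, only a limit, and it shares that position with the other two compounds (the limit of > 36600 nM in this assay, at which 3 of the 3 values shown sit). Compound 4 (`C=C[C@@](C)(/C=C/c1ccc(-c2cccc(Br)c2)cc1)CCC=C(C)C`) carries 3-bromophenyl in place of (3,4-dichlorophenyl)amino on an aromatic carbon. Going by the values given here, three measured steps bear on this change (a step that the two limits leave unreadable from compound 1 to compound 2) and (a step that the two limits leave unreadable from compound 1 to compound 3) and (a step that the two limits leave unreadable from compound 2 to compound 3), but none has a readable size. They therefore support no expected direction in this assay and no expected shift beyond the scatter. The estimated change is small (a number no higher from compound 3 to compound 4 (the limit leaves the size open)) and rests on thin evidence. Compound 4 is expected at about 36600 nM with an estimated range from 18000 nM to 73000 nM and may well return only a limit.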

Compound 4, half-maximal effective concentration: > 36600 nM
Compound 4 ended at the assay's limit; the forecaster's own chance of this, stated with the estimate: 85%; the middle value lies on the limit itself.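

Compound 4 returns only a limit, like compound 1, compound 2 and compound 3, so no step among them can be read in this assay: the limit of > 36600 nM in this assay, at which 4 of the 4 values shown sit.

The compounds shown leave open how much of each is needed for the effect, and whether changing the group on the aromatic carbon alters that amount at all.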